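This account rests on a few compounds, and the source may have more. Where it says the series, first, only, none or still open, it means among the compounds named here.

Of the compounds shown here, three sharing one core have been measured in a physicochemical assay for lipophilicity, read by HPLC; on this read-out higher numbers stand for higher lipophilicity and lower numbers for lower lipophilicity. Compound 1, `CCn1c(-c2cnc(C)nc2)nc2c(N[C@H]3CCN(C(=O)C4CCC4)C3)ncnc21`, gives 1.2. Compound 2, `CCn1c(-c2cnc(C)nc2)nc2c(N[C@H]3CCN(C(=O)C4CCOC4)C3)ncnc21`, gives 0.6. Compound 3, `CCn1c(-c2cnc(C)nc2)nc2c(N[C@H]3CCN(C(=O)N4CC(OC)C4)C3)ncnc21`, gives 0.7. Among these three numbers compound 3 sits second highest: its nearest neighbour is compound 2, and that gap is a number 0.10 log units higher from compound 2 to compound 3 (within the scatter), which is within the scatter, while its furthest neighbour is compound 1.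

Compound 4, `CCn1c(-c2cnc(C)nc2)nc2c(N[C@H]3CCN(C(=O)C4CC4)C3)ncnc21`, is not yet measured. The change from compound 3 to compound 4 is cyclopropyl in place of 3-methoxyazetidin-1-yl on a carbonyl carbon. Two measured steps speak to this. The step of a number 0.50 log units lower from compound 1 to compound 3 (beyond the scatter) shows that swapping a carbon-only ring on the carbonyl carbon for the 3-methoxyazetidin-1-yl group lowered this assay, and the step of a number 0.60 log units lower from compound 1 to compound 2 (beyond the scatter) shows a similar drop when an oxolan-3-yl ring took the place of cyclobutyl. Compound 4 goes the other way, returning to a carbon-only ring, though a three-membered one rather than the four-membered ring of compound 1. The expected step is therefore upward, a number 0.10 log units higher from compound 3 to compound 4 (within the scatter), which is beyond the scatter but not as far as compound 1. Compound 4 is estimated to give 0.8, within a range from 0.4 to 1.2.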

Compound 4, distribution coefficient: 0.8
Compound 4: the middle estimate sits on the measured number at the digits printed, and the stated range covers the measured number.
By their numbers in this assay, from the lowest: compounds 2, 3 and 4 (each within the scatter of the next); then compound 1.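

In this assay, a carbon-only ring on the carbonyl carbon proves not to be enough on its own to keep the number high: cyclopropyl in compound 4 cannot be told apart from the groups that carry a hetero atom, the steps being a number 0.10 log units higher from compound 3 to compound 4 (within the scatter) and a number 0.20 log units higher from compound 2 to compound 4 (within the scatter). The one clear step now lies between the two carbon-only rings, a number 0.40 log units lower from compound 1 to compound 4 (beyond the scatter), so among these four compounds the presence of a hetero atom in the group does not mark the dividing line, compound 4 being the one that goes against such a reading, and only the cyclobutyl of compound 1 stands apart. Nothing measured alongside these numbers accounts for that step.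

Within the data shown here, whether a cyclopentyl ring on the carbonyl carbon would carry the number further along the direction seen from cyclopropyl to cyclobutyl remains open, since two carbon-only rings give only a single step. Also open, as far as these compounds go, is where an open chain such as isopropyl, or a dimethylamino group in the same place, would fall relative to these four compounds.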